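Flipping the Linker Double Bond from Z to E

The source may hold more compounds than are shown below. What is called first, only, known or untested is meant among the compounds shown, and "the series" means these compounds.

Compound 1 `CCCCCCC#Cc1cn(C/C=C/CN2C(=O)c3ccccc3C2=O)c(=O)[nH]c1=O`: in a functional assay on MIA PaCa-2 cells (Homo sapiens) for antiproliferative activity, read by MTT assay, with a stated time of 3 days (a lower number here means a stronger inhibitor, a higher number a weaker inhibitor), compound 1 gives 30000 nM.
Compound 2 `O=C1c2ccccc2C(=O)N1C/C=C\Cn1cc(C#CCCc2ccccc2)c(=O)[nH]c1=O`: in this assay compound 2 gives > 100000 nM, which is a limit of the assay, not a number.

Compound 2 therefore stands at the limit, as the line the limit of > 100000 nM in this assay, at which 1 of the 2 values shown sits, records, while compound 1 sits at a measured value. Compound 3 `O=C1c2ccccc2C(=O)N1C/C=C/Cn1cc(C#CCCc2ccccc2)c(=O)[nH]c1=O` differs from compound 2 only in drawing: the two compounds have the same atoms and bonds and differ only in configuration as drawn: 1 of 1 stereo elements differ; a double bond is drawn Z in compound 2 and E in compound 3. Compound 1 also carries the E geometry and gives a measurable number, so for compound 3 a move out of the limit toward a measurable value is expected, the step being an at least 2.5-fold lower number from compound 2 to compound 3 (0.39 log units; beyond the scatter). Compound 3 is expected at 40000 nM, within 10000 nM to 150000 nM.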

Compound 3, half-maximal inhibitory concentration: 27000 nM
Compound 3: the middle estimate sits 1.5-fold (0.17 log units) above what was measured; the range from low to high includes it.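

In this assay, turning the linker double bond from Z to E gives an at least 3.7-fold lower number from compound 2 to compound 3 (0.56 log units; beyond the scatter), and this step rests on that double bond alone: the fact that compounds 2 and 3 differ only in the configuration as drawn. The value of compound 2 is a limit of the assay, not a number: the limit of > 100000 nM in this assay, at which 1 of the 3 values shown sits. With the E geometry kept, phenyl in place of butyl at the chain gives a 1.1-fold lower number from compound 1 to compound 3 (0.05 log units; within the scatter), so this swap shows no change that can be told from the scatter.

Still open, as far as these compounds go, is whether the Z to E step holds with the butyl chain. Also open, from the compounds shown here alone, is how an amine or a carboxylic acid at the chain end would read.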